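This account rests on a few compounds, and the source may have more. Where it says the series, first, only, none or still open, it means among the compounds named here.

In a functional assay on HeLa cells (Homo sapiens) for inhibition, read by MTT assay, with a stated time of 48 h (on this read-out higher numbers stand for weaker inhibition of growth and lower numbers for stronger inhibition of growth), compound 1 `COc1ccc(C(=O)N2N=C(c3ccccc3)CC2c2cn(C)c3ccccc23)cn1` gives 3980 nM and compound 2 `Cc1ccc(C(=O)N2N=C(c3ccccc3)CC2c2cn(C)c3ccccc23)cn1` gives 2390 nM so the two sit level and compound 2 holds no real lead. Compound 3 `Cn1cc(C2CC(c3ccccc3)=NN2C(=O)c2cccnc2Cl)c2ccccc21` carries 2-chloropyridin-3-yl in place of 6-methylpyridin-3-yl on a carbonyl carbon, and 2-chloropyridin-3-yl in place of 6-methylpyridin-3-yl on a carbonyl carbon sets out what that swap exchanges. Within the data shown here, the only measured step that bears on this is a 1.7-fold lower number from compound 1 to compound 2 (0.22 log units; within the scatter) for methyl in place of methoxy on an aromatic carbon, and no measured compound carries chlorine. Among the measured compounds shown here, with compound 2 at 2390 nM as the anchor and that small step as the only guide, no change beyond the scatter is expected, in either direction. The estimated shift is a 1.3-fold higher number from compound 2 to compound 3 (0.10 log units; within the scatter) with its direction uncertain. In this assay the expected value for compound 3 is 3000 nM with an estimated range from 1000 nM to 9000 nM as the likely span of repeat measurements.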

Compound 3, concentration for 50% growth inhibition: > 10000 nM
Compound 3: only a limit was reported; the forecaster's own chance of this, stated with the estimate: 5%; at least 3.3-fold (0.52 log units) between middle value and limit.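

In this assay compound 3 gives > 10000 nM, which is a limit of the assay and not a number. Even so, this is the first change in the series to move the read-out beyond the scatter, with an at least 4.1-fold higher number from compound 2 to compound 3 (0.62 log units; beyond the scatter) and an at least 2.5-fold higher number from compound 1 to compound 3 (0.40 log units; beyond the scatter), both towards weaker inhibition of growth. The group on the carbonyl carbon therefore matters: 6-methylpyridin-3-yl and 6-methoxypyridin-3-yl sit level, 2-chloropyridin-3-yl does worse than both, and the full size of that loss cannot be read because the value stops at a limit: the limit of > 10000 nM in this assay, at which 1 of the 3 values shown sits.

Whether the chlorine itself or its place on the ring accounts for the loss stays open, and a 6-chloropyridin-3-yl or 2-methylpyridin-3-yl group would separate the two. Also open, going by these compounds, is whether an amine, as in 6-aminopyridin-3-yl, would stay level with compound 1 and compound 2.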